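A few compounds are considered here, and "the series" means these few. Any claim that something is new, unique, unknown or untested is made for them only; others in the source may bear on it.

Working notes on a nitroimidazole-ethylthio series sharing one core, tested in a functional assay on SGC-7901 cells (Homo sapiens) for cytotoxicity, read by MTT assay, with a stated time of 48 h; on this read-out higher numbers stand for weaker inhibition and lower numbers for stronger inhibition.

Three compounds are in hand. Compound 1 `Cc1ncc([N+](=O)[O-])n1CCSc1nnc(-c2ccccc2F)o1` carries a 2-fluorophenyl on the core and gives 33700 nM in this assay. Compound 2 `Cc1ncc([N+](=O)[O-])n1CCSc1nnc(-c2ccc(N(C)C)cc2)o1` gives 32800 nM in this assay, and compound 3 `COc1cc(-c2nnc(SCCn3c([N+](=O)[O-])cnc3C)o2)cc(OC)c1OC` gives 34800 nM in this assay. The three numbers sit together: compound 1 is not separated from compound 2 or from compound 3 by more than the usual scatter, so no ordering among them can be read, and none is called stronger or weaker than another. For the measured compounds named here, no single-point step between measured compounds exists in this set, and the aryl groups differ from one another in several ways at once.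

Compound 4 `Cc1ncc([N+](=O)[O-])n1CCSc1nnc(-c2ccc(N)nc2)o1` is the next member, differing from compound 1 by 6-aminopyridin-3-yl in place of 2-fluorophenyl on an aromatic carbon. With the three measured aryl variants all giving numbers within scatter of one another, there is no basis in the data for expecting a shift beyond scatter in either direction; the expected step from compound 1 to compound 4 is a 1.0-fold higher number from compound 1 to compound 4 (0.02 log units; within the scatter), that is, none beyond scatter. Compound 4 is therefore estimated at 35000 nM in this assay, with a range of 15000 nM to 80000 nM.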

Compound 4, half-maximal inhibitory concentration: 30900 nM
For compound 4 the middle estimate is 1.1-fold (0.05 log units) above the measured one; measured number inside the range.
By their numbers in this assay, from the lowest: compounds 4, 2, 1 and 3 (each within the scatter of the next).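

For the compounds shown here, putting 6-aminopyridin-3-yl in place of 2-fluorophenyl on this aromatic carbon of the shared core gives the first single-place step, and in this assay it is a 1.1-fold lower number from compound 1 to compound 4 (0.04 log units; within the scatter). The series thus tolerates, with no change readable beyond the scatter, a swap that adds a ring nitrogen, an amino group, a hydrogen-bond donor and hydrogen-bond acceptors, and removes the fluorine, so at this place these differences in the group leave the read-out unresolved from the starting value. No independent measurement bears on this result.

On these data alone, all four compounds carry a six-membered aromatic ring at this place, so it remains open whether a cyclohexyl group, a plain methyl or a carboxylic acid on the aromatic ring would move the number beyond the scatter. Also open, as far as these compounds go, is whether the read-out responds to the rest of the molecule, for example a longer chain such as propyl in place of the ethyl link to the sulfur, since that link and the nitroimidazole stay the same throughout.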